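Adding a methyl to the hydroxy of compound 3

A few compounds are considered here, and "the series" means these few. Any claim that something is new, unique, unknown or untested is made for them only; others in the source may bear on it.

Of the compounds shown here, three have so far been measured in a functional assay on NCI-H157 cells (Homo sapiens) for antiproliferative activity, read by sulforhodamine B assay, with a stated time of 48 h, tested at 100 uM; a lower number here means less inhibition of growth, a higher number more inhibition of growth at the concentration tested. Compound 1 `Fc1ccc(OCc2nn3c(-c4ccncc4)nnc3s2)cc1` gives 32%, compound 2 `c1ccc2c(C3=Nn4c(nnc4-c4ccncc4)SC3)cccc2c1` gives 68.2%, and compound 3 `Oc1ccc(OCc2nn3c(-c4ccncc4)nnc3s2)cc1` gives 63.7%. Compound 3 therefore sits in the upper part of this small set: it cannot be told apart from compound 2 within the usual scatter, and it lies clearly above compound 1.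

Compound 4 `COc1ccc(OCc2nn3c(-c4ccncc4)nnc3s2)cc1` differs from compound 3 at a single place: methyl in place of hydrogen on an oxygen on an aromatic ring. This is methyl in place of hydrogen on an oxygen on an aromatic ring, which turns hydroxy into methoxy.

Going by the values given here, no measured pair shows this exact change. The closest guide is a number 31.7 percentage points higher from compound 1 to compound 3 (beyond the scatter), which comes from hydroxy in place of fluoro on an aromatic carbon. That single large step shows that swapping this one group can shift the result strongly, but it does not show where methoxy will fall. A landing somewhere between compound 1 and compound 3 seems the most reasonable expectation. The expected change is a number 13.7 percentage points lower from compound 3 to compound 4 (beyond the scatter), a moderate fall with real uncertainty. Compound 4 is estimated at 50%, with an expected range from 32% to 68%.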

Compound 4, percent growth inhibition at one concentration: 68.9%
Compound 4: the middle estimate sits 18.9 percentage points below what was measured; the whole stated range lies below it.
By their numbers in this assay, from the lowest: compound 1; then compounds 3, 2 and 4 (each within the scatter of the next).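

Going from hydroxy to methoxy in this assay gives a number 5.2 percentage points higher from compound 3 to compound 4 (within the scatter) and so shows that, in this pair, methyl can replace the hydrogen on this oxygen without a change that can be told from the scatter. Methoxy also gives a number 36.9 percentage points higher from compound 1 to compound 4 (beyond the scatter) and so, like hydroxy, stands well clear of fluoro, which means that the large gap to fluoro does not depend on keeping the hydrogen on the oxygen. Nothing available explains why hydroxy and methoxy read alike or why fluoro gives a much lower number.

Going by these compounds, whether this oxygen can carry something larger than methyl, such as an ethyl group or a longer chain, remains open, as does whether an amine in place of the oxygen group would read like hydroxy and methoxy or like fluoro. On these data alone, each number is also growth inhibition at a single concentration, so how these compounds would compare across a range of concentrations is unknown.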